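Series notes: bromo for methyl on the aryl ring

The source may report more compounds than this note shows. Statements on the series, on what has been measured and on what is new or still open speak of the compounds shown alone.

Within the data shown here, compound 3 `COC(=O)C1=C(C)N=C(C)/C(=C(\O)OC)C1c1ccccc1C` gives 6.03 nM in a functional assay (muscle tissue) with Cavia porcellus as the target (on this read-out lower numbers stand for an effect already at smaller amounts and higher numbers for an effect only at larger amounts of compound), the second highest of the three numbers known so far. Among the measured compounds shown here, compound 1 `C=Cc1ccccc1C1C(C(=O)OC)=C(C)N=C(C)/C1=C(\O)OC` gives 4.47 nM in this assay, and the two lie within the scatter of each other; the step of a 1.3-fold higher number from compound 1 to compound 3 (0.13 log units; within the scatter) is the only change at the same aromatic carbon measured to date. Compound 2 `COC(=O)C1=C(C)N=C(C)/C(=C(\O)OC)C1c1ccc(Cl)cc1Cl` gives 640 nM in this assay; the step of a 110-fold lower number from compound 2 to compound 3 (2.03 log units; beyond the scatter) alters two ring positions at once and so bears on the present change only loosely. Compound 4 `COC(=O)C1=C(C)N=C(C)/C(=C(\O)OC)C1c1ccccc1Br` differs from compound 3 in one place: bromo in place of methyl on an aromatic carbon. Bromo enters where methyl sat, ortho to a large group. The comparable one-site change, a 1.3-fold higher number from compound 1 to compound 3 (0.13 log units; within the scatter), stayed within the scatter, while the large step from compound 2 rests on two substituents and leaves the weight of one halogen open. A step of a 1.3-fold higher number from compound 3 to compound 4 (0.12 log units; within the scatter) is therefore expected, with no change beyond the scatter as the most likely outcome. Compound 4 is estimated at 8 nM, within 2.5 nM to 30 nM.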

Compound 4, half-maximal effective concentration: 7.59 nM
Compound 4: the middle estimate sits 1.1-fold (0.02 log units) above what was measured; measured number inside the range.
By their numbers in this assay, from the lowest: compounds 1, 3 and 4 (each within the scatter of the next); then compound 2.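

In this assay the step of a 1.3-fold higher number from compound 3 to compound 4 (0.10 log units; within the scatter) shows that bromo can replace methyl on this aromatic carbon, ortho to a large group, without a change beyond the scatter, and the step of a 1.7-fold higher number from compound 1 to compound 4 (0.23 log units; within the scatter) shows the same for bromo in place of vinyl. The step of an 84-fold lower number from compound 2 to compound 4 (1.93 log units; beyond the scatter) remains large, so a halogen on the aryl ring does not by itself go with the high number of compound 2, although this step changes two ring positions at once. No measured property is available to account for these results.

On these data alone, it remains open whether an amine, a carboxylic acid or a longer chain on this aromatic carbon would also stay within the scatter. As far as these compounds go, it also remains open how 2-chlorophenyl and 4-chlorophenyl would each compare with 2,4-dichlorophenyl.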